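The source may hold more compounds than are shown below. What is called first, only, known or untested is meant among the compounds shown, and "the series" means these compounds.

Compound 2, whose structure is `O=C(CSC(=S)N[C@H]1CCOC1=O)Nc1ccccc1`, was examined in a functional assay on SMMC-7721 cells (Homo sapiens) for cytotoxicity, read by MTT assay, with a stated time of 72 h; on this read-out higher numbers stand for weaker inhibition and lower numbers for stronger inhibition. For compound 2 the result is a limit of the assay rather than a number, > 128000 nM. Compound 1, `O=C(CSC(=S)N[C@H]1CCOC1=O)Nc1ccc(Br)cc1`, carries the change bromo in place of hydrogen on an aromatic carbon relative to compound 2, and in this assay compound 1 gives 28300 nM. The step is an at least 4.5-fold lower number from compound 2 to compound 1 (0.65 log units; beyond the scatter), and it is stated only as a floor because the limit of > 128000 nM in this assay, at which 1 of the 3 values shown sits, is where compound 2 sits.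

Compound 3, `O=C(CCl)Nc1ccc(C(=O)/C=C/c2ccccc2)cc1`, rests on a different core; how its core differs from that of compound 2 is not broken down here. In this assay compound 3 gives 12600 nM, the lowest of the two numbers shown, and it lies beyond the scatter from compound 1.

Compound 4, `O=C(CCl)Nc1ccc(C(=O)/C=C/c2ccc(Br)cc2)cc1`, has not yet been measured. It differs from compound 3 by bromo in place of hydrogen on an aromatic carbon. The place of the change reads the same, word for word, as it does between compound 2 and compound 1, so this is the same change made on another core. Within the data shown here, only one instance of this change is measured, and on a core that is not broken down against that of compound 3, so the earlier step is taken as a guide rather than a rule. For compound 4 in this assay the expected step is a 2.5-fold lower number from compound 3 to compound 4 (0.40 log units; beyond the scatter), smaller than the measured one because an at least 4.5-fold lower number from compound 2 to compound 1 (0.65 log units; beyond the scatter) is itself only a floor from a limit. The estimate for compound 4 is 5000 nM, with a likely span from 1500 nM to 15000 nM.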

Compound 4, half-maximal inhibitory concentration: 13300 nM
Compound 4: middle estimate off by 2.7-fold (0.42 log units), on the low side; measured number inside the range.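

On the core of compound 3, compound 3 and compound 4 cannot be told apart in this assay, the step being a 1.1-fold higher number from compound 3 to compound 4 (0.02 log units; within the scatter). Set beside the step on the core of compound 2, this shows that the same change, phenyl to 4-bromophenyl, did not carry over from one core to the other in this series: the same change on two cores in this assay, an at least 4.5-fold lower number (0.65 log units; beyond the scatter) from compound 2 to compound 1 and a 1.1-fold higher number (0.02 log units; within the scatter) from compound 3 to compound 4, at least 4.7-fold (0.67 log units) apart, beyond the scatter of two such steps It does not show why the two cores part ways, and with a single pair on each core it gives no rule for any further core, while the earlier step is only a floor, since compound 2 stands at a limit of the assay: the limit of > 128000 nM in this assay, at which 1 of the 4 values shown sits.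

The compounds shown carry only hydrogen or bromo at this place on the aromatic ring, so it stays open whether chloro, methoxy or a carboxylic acid there would give a step on one core that also holds on the other. As far as these compounds go, it also stays open whether an amine in place of the chloro group shared by compound 3 and compound 4 would leave the bromo step on that core as it reads here.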